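From butyl to chloro at the assay limit

A few compounds are considered here, and "the series" means these few. Any claim that something is new, unique, unknown or untested is made for them only; others in the source may bear on it.

In an ADME assay on LL24 cells (Homo sapiens) for inhibition, read by MTT assay, with a stated time of 24 h (a lower number here means a stronger inhibitor, a higher number a weaker inhibitor), compound 1 (`CCCCc1ccc(C(=O)N/N=C/c2ccc([N+](=O)[O-])o2)cc1`) gives > 200000 nM as a limit of the assay and not a number. Compound 2 (`O=C(N/N=C/c1ccc([N+](=O)[O-])o1)c1ccccc1Oc1ccccc1`) gives > 200000 nM as a limit as well. Compound 3 (`CC(C)(C)OC(=O)N/N=C/c1ccc([N+](=O)[O-])o1`) gives > 200000 nM as a limit too. Compound 1 therefore has no numerical position among these compounds, and the shared reading is the limit of > 200000 nM in this assay, at which 3 of the 3 values shown sit, with no number behind it.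

Compound 4 (`O=C(N/N=C/c1ccc([N+](=O)[O-])o1)c1ccc(Cl)cc1`) has chloro in place of butyl on an aromatic carbon, para to a large group (chloro in place of butyl on an aromatic carbon). Among the compounds with values here, no measured pair differs in one place, so this assay offers no direct measure of such a change. The expected size of the change a number no higher from compound 1 to compound 4 (the limit leaves the size open) is none beyond the usual scatter, in either direction. This expectation rests on compound 1 with its limit of > 200000 nM as the only anchor. For compound 4 the estimated value is 200000 nM within an expected range of 80000 nM to 400000 nM and the assay may again report only a limit.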

Compound 4, half-maximal inhibitory concentration: 187000 nM
Compound 4: the middle estimate sits 1.1-fold (0.03 log units) above what was measured; the measured number falls inside the stated range.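

Within the data shown here, with chloro in place of butyl on an aromatic carbon, para to a large group, compound 4 gives 187000 nM in this assay, the first reading here that is a number and not a limit. The change amounts to an at least 1.0-fold lower number from compound 1 to compound 4 (0.02 log units; that floor lies within the scatter), which is only a floor. Going by these compounds, compound 1 has only a limit, so the true size of this step stays open, and it cannot be said that chloro changes the reading at this position in either direction. Compound 4 thus gives the series one numerical anchor, while most of the readings remain limits: the limit of > 200000 nM in this assay, at which 3 of the 4 values shown sit.

On these data alone, whether an amine, a carboxylic acid or a longer chain on this same aromatic carbon would give a number remains open. As far as these compounds go, whether bromo or methoxy would read like chloro also remains open.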